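The source may report more compounds than this note shows. Statements on the series, on what has been measured and on what is new or still open speak of the compounds shown alone.

Compounds measured so far:
compound 1 `Cc1nc(C(NC(=O)C(=O)Nc2ccc(Cl)cc2)C2CCCN2)sc1CO` — 12400 nM
compound 2 `Cc1nc(C(NC(=O)C(=O)Nc2ccc(Cl)cc2)C2CCCCN2)sc1CO` — > 22000 nM
compound 3 `Cc1nc(C(NC(=O)C(=O)Nc2ccc(Cl)cc2)C2CCCNC2)sc1CO` — 60200 nM

In an ADME assay on TZM-b1 cells (Homo sapiens) for cytotoxicity, read by XTT assay, with a stated time of 3 days (on this read-out lower numbers stand for higher toxicity in this test and higher numbers for lower toxicity in this test), compound 1 gives 12400 nM, the lowest number of the two numbers available; the nearest is compound 3, reached by a 4.9-fold higher number from compound 1 to compound 3 (0.69 log units; beyond the scatter). The value of compound 2 in this assay is a limit, (the limit of > 22000 nM in this assay, at which 1 of the 3 values shown sits), so the step of an at least 1.7-fold higher number from compound 1 to compound 2 (0.24 log units; that floor lies within the scatter) has only a floor, and the step that the limit leaves unreadable from compound 2 to compound 3 cannot be sized.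

Compound 4 `Cc1nc(C(NC(=O)C(=O)Nc2ccc(Cl)cc2)C2CCCN2)sc1CCO` is not yet measured. It differs from compound 1 by hydroxymethyl in place of hydroxy on a saturated chain carbon bound to an aromatic carbon; read one bond further out, hydroxymethyl becomes 2-hydroxyethyl on the core of compound 1. All three measured steps alter the saturated amine ring on the chain carbon and leave this side of the molecule untouched, so none of them bears directly on the change to compound 4. Within the data shown here, the one readable step, from compound 1 to compound 3, is modest even for a ring change; the chain extension here is smaller in kind. The expectation in this assay is therefore no step beyond the scatter, with the limit of the assay a real possibility.

Compound 4 is estimated at 14000 nM, range 5000 nM to 40000 nM, an expected step of a 1.1-fold higher number from compound 1 to compound 4 (0.05 log units; within the scatter).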

Compound 4, half-maximal cytotoxic concentration: 4900 nM
Estimate against measurement, compound 4: 2.9-fold (0.46 log units) above; measured number below the stated range.
By their numbers in this assay, from the lowest: compound 4; then compound 1; then compound 3.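

In this assay, replacing hydroxymethyl with 2-hydroxyethyl on the core of compound 1 gives a 2.5-fold lower number from compound 1 to compound 4 (0.40 log units; beyond the scatter) and so shows that this side of the molecule, untouched by the earlier changes to the saturated amine ring, also moves the read-out beyond the scatter. Among these compounds, the direction is toward higher toxicity in this test, whereas the one readable ring step, a 4.9-fold higher number from compound 1 to compound 3 (0.69 log units; beyond the scatter), runs toward lower toxicity in this test, so the two places can shift the number in opposite directions. The compounds shown offer no measured basis for assigning a cause to the change at the hydroxymethyl position.

Going by these compounds, one pair cannot establish a trend with chain length, so it remains open whether a longer chain such as 3-hydroxypropyl would lower the number further, or whether a carboxylic acid or an amine at the end of the chain would reverse the step. On these data alone, it also remains open whether 2-hydroxyethyl would produce a step of similar size and direction on the piperidin-2-yl and piperidin-3-yl compounds.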